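The compounds below may be only part of what the source reports. "The series", "measured", "known", "first", "only" and "open" are said of these compounds alone.

Series notes, cytotoxicity screen.

Compound 1 `COC(=O)[C@H](CO)NC(=O)c1cnc2ccccc2c1Cl` and compound 2 `COC(=O)[C@H](CO)NC(=O)c1cnc2ccc(Cl)cc2c1Cl` share one core; compound 3 `O=C(NCCO)c1c[nH]c2ccccc2c1=O` and the unmeasured compound 4 `O=C(NCCO)c1c[nH]c2ccc(Cl)cc2c1=O` share another. The difference between the two cores is not broken down here. All measured values come from an ADME assay on CCRF-CEM cells (Homo sapiens) for cytotoxicity; on this read-out higher numbers stand for lower toxicity in this test and lower numbers for higher toxicity in this test.

In this assay compound 1 gives > 100 uM, which is a limit of the assay rather than a number. In this assay compound 2 gives > 100 uM, again a limit. The change between them is chloro in place of hydrogen on an aromatic carbon. The step it produced, a step that the two limits leave unreadable from compound 1 to compound 2, cannot be read because both ends sit at a limit.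

In this assay compound 3 gives > 100 uM, also a limit. Compound 4 differs from compound 3 by chloro in place of hydrogen on an aromatic carbon. This is the same change as the one from compound 1 to compound 2, at a place described in the same words, and it occurs twice among the compounds shown.

The step from compound 3 to compound 4 is expected to be small, a step that the limit leaves unreadable from compound 3 to compound 4, because the limit of > 100 uM in this assay, at which 3 of the 3 values shown sit, shows every value in this series sitting at the same limit, so the earlier occurrence of this change gave no readable shift that could be carried over. No measured value in the series falls below the limit, so there is no counter-example to a flat outcome.

Compound 4 is accordingly estimated at 150 uM in this assay, with a range from 50 uM to 500 uM, most likely reported again as a limit.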

Compound 4, half-maximal toxic concentration: > 100 uM
Compound 4: a limit, no number; the forecaster's own chance of this, stated with the estimate: 85%; the middle value lies beyond the limit too.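

No step can be read from compound 3 to compound 4 in this assay, as both ends are limits rather than numbers: the limit of > 100 uM in this assay, at which 4 of the 4 values shown sit.

The compounds shown leave open whether chloro in place of hydrogen on an aromatic carbon changes the half-maximal toxic concentration on either core, and whether the two cores differ at all in this assay.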